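This account rests on a few compounds, and the source may have more. Where it says the series, first, only, none or still open, it means among the compounds named here.

Compound 3, with the structure `CCCCSc1nnc(COc2cc(C)c3c(C)cc(=O)oc3c2)o1`, carries a chain of three saturated carbons on the sulfur of the shared core. In a functional assay on MDA-MB-231 cells (Homo sapiens) for antiproliferative activity, read by MTT assay, with a stated time of 24 h (on this read-out lower numbers stand for stronger inhibition and higher numbers for weaker inhibition), compound 3 gives > 100000 nM, which is a limit of the assay rather than a measured number. Two smaller relatives share this core. Compound 1 has the structure `CSc1nnc(COc2cc(C)c3c(C)cc(=O)oc3c2)o1`, and in this assay compound 1 gives > 100000 nM, again a limit. Compound 2 has the structure `CCSc1nnc(COc2cc(C)c3c(C)cc(=O)oc3c2)o1`, and in this assay compound 2 gives > 100000 nM, also a limit. The three chain-lengthening steps a step that the two limits leave unreadable from compound 1 to compound 2, a step that the two limits leave unreadable from compound 1 to compound 3 and a step that the two limits leave unreadable from compound 2 to compound 3 therefore cannot be sized, because of the limit of > 100000 nM in this assay, at which 3 of the 3 values shown sit.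

Compound 4, with the structure `CCCCCCSc1nnc(COc2cc(C)c3c(C)cc(=O)oc3c2)o1`, extends the chain once more: ethyl in place of hydrogen on a saturated chain carbon, four bonds along the chain from a sulfur. Every measured step on this chain was unreadable, so the step that the limit leaves unreadable from compound 3 to compound 4 from compound 3 to compound 4 is expected to be small or absent. Compound 4 is thus expected to give about 200000 nM in this assay, within a range from 50000 nM to 1000000 nM.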

Compound 4, half-maximal inhibitory concentration: > 100000 nM
Compound 4 gave a limit, no number; the forecaster's own chance of this, stated with the estimate: 85%; the middle value lies beyond the limit too.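

Compound 4 also stops at a limit of the assay, so its steps from compound 1, compound 2 and compound 3 cannot be read: the limit of > 100000 nM in this assay, at which 4 of the 4 values shown sit. The compounds shown leave open whether, in this assay, any chain on the sulfur of the shared core gives a measured number rather than a limit.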